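Adding Chlorine to a Carbamate: Expected Cell Inhibition

The source may report more compounds than this note shows. Statements on the series, on what has been measured and on what is new or still open speak of the compounds shown alone.

Compound 2 `CC(C)=CCC1Cc2c(OC(=O)Nc3ccc(F)cc3)cc(=O)n(CCCO)c2CC1(C)C` gives the higher of the two numbers in a functional assay on PANC-1 cells (Homo sapiens) for inhibition, read by MTT assay, with a stated time of 24 h, tested at 10 uM; a lower number here means less inhibition, a higher number more inhibition at the concentration tested (going by the name of the read-out): compound 2 shows 71.2%, whereas compound 1 `CC(C)=CCC/C(C)=C/COc1cc(=O)n(CCCO)c2c1CC(CC=C(C)C)C(C)(C)C2` shows 10.6%. For the measured compounds named here, the only measured step, a number 60.6 percentage points higher from compound 1 to compound 2 (beyond the scatter), is large but concerns a different part of the molecule. Compound 3 `CC(C)=CCC1Cc2c(OC(=O)Nc3ccc(F)c(Cl)c3)cc(=O)n(CCCO)c2CC1(C)C` differs from compound 2 by a smaller change: chloro in place of hydrogen on an aromatic carbon. Going by the values given here, no measured step covers such a chloro addition, so no shift beyond the scatter is expected, giving an estimated a number 1.8 percentage points higher from compound 2 to compound 3 (within the scatter). Compound 3 is therefore expected to give 73%, in the range 58% to 86%.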

Compound 3, a percentage reported as inhibition, at one concentration (the size of the read-out at that concentration, not a potency): 79.8%
Compound 3: middle estimate off by 6.8 percentage points, on the low side, within the range that was stated.
By their numbers in this assay, from the lowest: compound 1; then compounds 2 and 3 (each within the scatter of the next).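

In this assay, chloro in place of hydrogen on the aromatic carbon ortho to a fluoro group gives a number 8.6 percentage points higher from compound 2 to compound 3 (within the scatter), so at this position the added chlorine costs no inhibition beyond the scatter. The (3-chloro-4-fluorophenyl)carbamoyl group also keeps a large gain over the 3,7-dimethylocta-2,6-dien-1-yl group, with a number 69.2 percentage points higher from compound 1 to compound 3 (beyond the scatter). On these data alone, whether a bromo, a methoxy or an amine at this same position would hold that level of inhibition remains open. Nothing measured here accounts for the size of either step.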